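This account rests on a few compounds, and the source may have more. Where it says the series, first, only, none or still open, it means among the compounds named here.

In an ADME assay on microsomes from liver (Mus musculus, strain CD-1) for metabolic stability, read by LC-MS, tested at 2 uM (a lower number here means that the compound disappears faster, a higher number that the compound lasts longer), compound 3 (`Cn1ccc2ccc(-c3cc(Nc4cnccc4C(=O)NCc4cncnc4)cc4nccnc34)cc21`) gives 0.4 h and stays within the scatter of compound 1 (`Cn1ccc2ccc(-c3cc(Nc4ccccc4S(N)(=O)=O)cc4nccnc34)cc21`) with 0.5 h and of compound 2 (`CN(Cc1cncnc1)S(=O)(=O)c1ccccc1Nc1cc(-c2ccc3ccn(C)c3c2)c2nccnc2c1`) with 0.2 h as well. Compound 4 (`CC(=O)N1CCC(NC(=O)c2ccncc2Nc2cc(-c3ccc4ccn(C)c4c3)c3nccnc3c2)CC1`) has 1-acetylpiperidin-4-yl in place of (pyrimidin-5-yl)methyl on an amide-type nitrogen. Going by the values given here, the one measured step involving the leaving group is modest but beyond the scatter (a 2.5-fold lower number from compound 1 to compound 2 (0.40 log units; beyond the scatter)). That step put methyl((pyrimidin-5-yl)methyl)amino in place of amino on a sulfonyl sulfur, so it bears only loosely on this change. Among the compounds with values here, no measured compound carries 1-acetylpiperidin-4-yl. No step beyond the scatter is expected, and no direction is favoured (no change at the digits printed from compound 3 to compound 4 (within the scatter)). For compound 4 the estimated half-life is 0.4 h (expected range 0.2 h to 0.8 h).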

Compound 4, half-life: 0.117 h
Beside the measured number, compound 4's estimate is 3.4-fold (0.53 log units) above it; measured number outside the range, below it.
By their numbers in this assay, from the lowest: compounds 4, 2, 3 and 1 (each within the scatter of the next, the first and the last beyond it).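

In this assay, the group on this amide-type nitrogen proves able to move the half-life beyond the scatter: 1-acetylpiperidin-4-yl in place of (pyrimidin-5-yl)methyl gives a 3.4-fold lower number from compound 3 to compound 4 (0.53 log units; beyond the scatter). Going by these compounds alone, this is the only measured step at this position, so it rests on one pair. Nothing measured bears on the reason for this fall. The compounds shown leave open whether the fall follows the acetyl group, the non-aromatic ring or the departure of the pyrimidine. A piperidin-4-yl with a free amine, or a cyclohexyl group, on the same nitrogen would begin to separate these.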